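This account rests on a few compounds, and the source may have more. Where it says the series, first, only, none or still open, it means among the compounds named here.

Values so far in a functional assay on BaF3 cells (Mus musculus) for antiproliferative activity, read by CCK-8 assay and cell counting, with a stated time of 76 h; on this read-out higher numbers stand for weaker inhibition and lower numbers for stronger inhibition

compound 1 `COc1cc2nccc(Oc3ccc(Nc4nn(C)cc4C(=O)NC4CCCCC4)cc3)c2cc1C(N)=O` gives 4800 nM
compound 2 `COc1cc2nccc(Oc3ccc(Nc4nn(C)cc4C(=O)NC4CCCCCCC4)cc3)c2cc1C(N)=O` gives 3210 nM
compound 3 `COc1cc2nccc(Oc3ccc(Nc4nn(C)cc4C(=O)NCC(C)C)cc3)c2cc1C(N)=O` gives > 10000 nM as a limit of the assay, not a number

Compound 2 sits with compound 1 at the low end of the numbers, and the two cannot be told apart (measured: a 1.5-fold lower number from compound 1 to compound 2 (0.17 log units; within the scatter)). The isobutyl amide stands clear of both (an at least 2.0-fold higher number from compound 1 to compound 3 (0.31 log units; beyond the scatter) and an at least 3.1-fold higher number from compound 2 to compound 3 (0.49 log units; beyond the scatter)), and these two steps rest on a limit.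

Next in line is compound 4 `COc1cc2nccc(Oc3ccc(Nc4nn(C)cc4C(=O)NCC4CCCCC4)cc3)c2cc1C(N)=O`, with cyclohexylmethyl in place of cyclooctyl on an amide-type nitrogen. Among the compounds with values here, the entering group keeps the six-membered ring of compound 1, but no measured step covers a ring carried on a methyl link. Changing one ring for another at this nitrogen stayed within the scatter in compound 2 (a 1.5-fold lower number from compound 1 to compound 2 (0.17 log units; within the scatter)). Replacing the ring with isobutyl in compound 3 cost more (an at least 3.1-fold higher number from compound 2 to compound 3 (0.49 log units; beyond the scatter)). Compound 4 still has its ring, so it is expected to stay nearer the two ring compounds than the limit of compound 3. In this assay the expected step is a small rise in the number (a 1.9-fold higher number from compound 2 to compound 4 (0.27 log units; within the scatter)). For compound 4 the expected value is 6000 nM (estimated range 2500 nM to 12000 nM).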

Compound 4, half-maximal inhibitory concentration: > 10000 nM
Compound 4 was reported as a limit; the forecaster's own chance of this, stated with the estimate: 25%; middle value at least 1.6-fold (0.22 log units) from the limit.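

In this assay, keeping a ring at this amide-type nitrogen is not enough to hold the level of the ring compounds: cyclohexylmethyl gives an at least 3.1-fold higher number from compound 2 to compound 4 (0.49 log units; beyond the scatter) and an at least 2.0-fold higher number from compound 1 to compound 4 (0.31 log units; beyond the scatter), and both steps rest on a limit rather than a number. Among the compounds shown, compound 1 and compound 2, with the ring bound directly to the amide-type nitrogen, give numbers, while compound 3 and compound 4, with a saturated chain carbon on that nitrogen, share the upper limit: the limit of > 10000 nM in this assay, at which 2 of the 4 values shown sit. With a limit on each side, the step from compound 3 to compound 4 cannot be read, so cyclohexylmethyl and isobutyl cannot be ranked against each other.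

Still open, going by these compounds, is whether the direct ring attachment is what separates these two pairs, which a cyclopentyl or cycloheptyl group on the same nitrogen would help test. Also open, on these data alone, is whether a ring carrying a heteroatom, such as piperidin-4-yl or tetrahydropyran-4-yl, or an aromatic phenyl group at this nitrogen would give a number at all in this assay.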